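Swapping One Aryl Group on the Strongest Compound

The source may report more compounds than this note shows. Statements on the series, on what has been measured and on what is new or still open speak of the compounds shown alone.

Compound 1 (`COc1cccc(/C=C/C(=O)/C=C(O)/C=C/c2cccc(OC)c2OC)c1OC`) gives 12800 nM in a functional assay on CNE-2 cells (Homo sapiens) for antiproliferative activity, read by sulforhodamine B assay, with a stated time of 48 h (on this read-out lower numbers stand for stronger inhibition and higher numbers for weaker inhibition), and compound 2 (`COc1ccc(OC)c(/C=C/C(=O)/C=C(O)/C=C/c2cc(OC)ccc2OC)c1`) gives 14700 nM there, so these two sit within the usual scatter of each other. Compound 3 (`COc1cccc(C=C(C(=O)/C=C/c2cccc(OC)c2OC)C(=O)/C=C/c2cccc(OC)c2OC)c1OC`), built on a different core, stands lowest of the three at 400 nM on the same read-out, clear of the scatter from both others, and so is the strongest inhibitor measured so far.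

Among the measured compounds shown here, compound 4 (`COc1ccc(C=C(C(=O)/C=C/c2cccc(OC)c2OC)C(=O)/C=C/c2cccc(OC)c2OC)cc1O`) has no measurement yet and differs from compound 3 in one place: a 3-hydroxy-4-methoxyphenyl group takes the place of a 2,3-dimethoxyphenyl group on a double-bonded chain carbon bound to a double-bonded chain carbon (3-hydroxy-4-methoxyphenyl in place of 2,3-dimethoxyphenyl on a double-bonded chain carbon bound to a double-bonded chain carbon). The rest of the molecule stays as it is.

For the measured compounds named here, no measured pair here isolates this swap, so the judgement rests on little. Compound 4 keeps the core of compound 3 (400 nM) rather than that of compound 1 (12800 nM), so a value near the lower of these is expected. The step expected in this assay is small and upward, a 1.5-fold higher number from compound 3 to compound 4 (0.18 log units; within the scatter) and probably inside the scatter. Compound 4 is estimated at 600 nM with an expected range from 180 nM to 2000 nM once it is tested.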

Compound 4, half-maximal inhibitory concentration: 220 nM
The estimate for compound 4 lay 2.7-fold (0.44 log units) above the measured number; measured number inside the range.
By their numbers in this assay, from the lowest: compounds 4 and 3 (each within the scatter of the next); then compounds 1 and 2 (each within the scatter of the next).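

Moving from the 2,3-dimethoxyphenyl group to the 3-hydroxy-4-methoxyphenyl group on a double-bonded chain carbon bound to a double-bonded chain carbon gives a 1.8-fold lower number from compound 3 to compound 4 (0.26 log units; within the scatter) in this assay, so this single change leaves the read-out within the usual scatter. Among the compounds shown here, this is the first view of how this position responds to a change, as compounds 1 and 2 differ from compound 3 in more than one place: here, the six-membered aromatic ring of carbon stays, while the substituents on it can change and the entering group can bring 1 hydrogen-bond donor where the leaving group has 0, with no change beyond the scatter. Nothing available explains why the read-out holds steady across this swap.

The swap changes the hydroxyl and the methoxy pattern together, so a single step cannot show what each contributes alone, and a 3-hydroxyphenyl or a 4-methoxyphenyl group at this place would separate them. On these data alone, it also remains open whether this position would accept a group of a different kind, such as an aminophenyl group, a carboxylic acid or a longer alkyl chain in place of the aryl ring.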